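Adding a methyl: from compound 3 to compound 4

This account rests on a few compounds, and the source may have more. Where it says the series, first, only, none or still open, it means among the compounds named here.

Within the data shown here, in a functional assay on SK-MEL-28 cells (Homo sapiens) for inhibition, read by colorimetric assay and MTT assay, with a stated time of 72 h (on this read-out lower numbers stand for stronger inhibition and higher numbers for weaker inhibition), compound 3 `Oc1ccc(-c2nnc(Nc3csc(-c4ccccc4)c3)s2)cc1` gives 57000 nM, the only full number in the set. Compound 1 `Cc1ccc(-c2cc(Nc3nnc(-c4ccc(C)cc4)s3)cs2)cc1` reaches only a limit in this assay, namely > 100000 nM. For compound 2 `COc1ccc(-c2nnc(Nc3csc(-c4ccc(C)cc4)c3)s2)cc1` no result is reported in this assay ("not determined" (no result reported)). Compound 4 `Cc1ccc(-c2cc(Nc3nnc(-c4ccc(O)cc4)s3)cs2)cc1` differs from compound 3 by methyl in place of hydrogen on an aromatic carbon. Among the measured compounds shown here, no measured pair shows this single change, so its size is not known from the data; with compound 1 sitting at the limit of > 100000 nM in this assay, at which 1 of the 3 values shown sits, the change is expected to be small, within the scatter or somewhat toward weaker inhibition. The step from compound 3 to compound 4 is estimated as a 1.3-fold higher number from compound 3 to compound 4 (0.12 log units; within the scatter). For compound 4 the expected value in this assay is 75000 nM, between 25000 nM and 200000 nM.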

Compound 4, half-maximal inhibitory concentration: 14000 nM
Estimate against measurement, compound 4: 5.4-fold (0.73 log units) above, outside the stated range (below it).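

In this assay, the change from phenyl to 4-methylphenyl is not neutral with the hydroxy group in place: a 4.1-fold lower number from compound 3 to compound 4 (0.61 log units; beyond the scatter). Hydroxy in place of methyl on an aromatic carbon also counts, giving an at least 7.1-fold lower number from compound 1 to compound 4 (0.85 log units; beyond the scatter). The reference point for that second step, compound 1, is a limit and not a number: the limit of > 100000 nM in this assay, at which 1 of the 4 values shown sits.

Going by these compounds, the methyl step rests on a single pair, so whether it holds with other groups at the hydroxy position stays open. Also open, on these data alone, is whether an ethyl chain or an amine in place of the methyl would go the same way.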